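A Propyl Group Added to a Weakly Active Core

The source may hold more compounds than are shown below. What is called first, only, known or untested is meant among the compounds shown, and "the series" means these compounds.

Among the compounds with values here, compound 2 `Cc1ncc2cnnc(O)n12` is one of three compounds tested so far in a functional assay for inhibition, with Homo sapiens as the target; on this read-out lower numbers stand for stronger inhibition and higher numbers for weaker inhibition. In this assay compound 2 reaches only a limit of the assay, > 48000 nM. Compound 1 `C=CCSc1nncc2cnc(C)n12` gives 61000 nM in this assay. Compound 3 `Oc1nncc2cncn12` likewise reaches only a limit, > 48000 nM. Compound 4 `CCCc1nc(C)n2c(O)nncc12` has not been measured; it differs from compound 2 by propyl in place of hydrogen on an aromatic carbon. The measured steps a step that the limit leaves unreadable from compound 1 to compound 2 and a step that the two limits leave unreadable from compound 2 to compound 3 cannot be sized because the limit of > 48000 nM in this assay, at which 2 of the 3 values shown sit, hides them, and neither touches the place where the propyl enters. With nothing to point to a change, compound 4 is expected to show a step that the limit leaves unreadable from compound 2 to compound 4 in this assay. Compound 4 is therefore estimated at 50000 nM, with a range from 15000 nM to 150000 nM.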

Compound 4, half-maximal inhibitory concentration: > 48000 nM
Compound 4: only a limit was reported (the forecaster's own chance of this, stated with the estimate: 60%); the middle value does not contradict the limit.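

Compound 2 and compound 4 both reach only a limit in this assay, so no step between them can be read: the limit of > 48000 nM in this assay, at which 3 of the 4 values shown sit.

On these data alone, whether propyl in place of hydrogen changes inhibition at all remains open.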